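A few compounds are considered here, and "the series" means these few. Any claim that something is new, unique, unknown or untested is made for them only; others in the source may bear on it.

In a functional assay on MCF7 cells (Homo sapiens) for cytotoxicity, read by sulforhodamine B assay, with a stated time of 48 h (on this read-out lower numbers stand for stronger inhibition and higher numbers for weaker inhibition), three compounds have been tested so far. Compound 1 `COc1ccc2c(c1)c(C=O)cn2Cc1cn([C@@H]2O[C@H](COC(C)=O)[C@@H](OC(C)=O)[C@H](OC(C)=O)[C@H]2OC(C)=O)nn1` gives > 200000 nM, which is a limit of the assay rather than a number. Compound 2 `COc1ccc2c(c1)c(/C=C1/C(=O)Nc3ccc(F)cc31)cn2Cc1cn([C@@H]2O[C@H](COC(C)=O)[C@@H](OC(C)=O)[C@H](OC(C)=O)[C@H]2OC(C)=O)nn1` gives > 200000 nM, again a limit and not a number. Going by the values given here, compound 3 `CC(=O)OC[C@H]1O[C@@H](n2cc(CN3C(=O)/C(=C\c4ccccc4)c4ccccc43)nn2)[C@H](OC(C)=O)[C@@H](OC(C)=O)[C@@H]1OC(C)=O` gives 24300 nM, the only real number among the three, so it stands alone with nothing measured to compare against. Among the compounds with values here, the single measured step, a step that the two limits leave unreadable from compound 1 to compound 2, cannot be read because of the limit of > 200000 nM in this assay, at which 2 of the 3 values shown sit. Compound 4 `CC(=O)OC[C@H]1O[C@@H](n2cc(CN3C(=O)/C(=C/c4ccccc4)c4ccccc43)nn2)[C@H](OC(C)=O)[C@@H](OC(C)=O)[C@@H]1OC(C)=O` differs from compound 3 only as follows: the two compounds have the same atoms and bonds and differ only in configuration as drawn: 1 of 6 stereo elements differ; a double bond is drawn Z in compound 3 and E in compound 4. Within the data shown here, no measured step touches such a change of double-bond geometry, so the expected step is no change at the digits printed from compound 3 to compound 4 (within the scatter), not beyond the scatter. Compound 4 is therefore estimated at 24300 nM, within 8000 nM to 80000 nM.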

Compound 4, half-maximal inhibitory concentration: 30200 nM
For compound 4 the middle estimate is 1.2-fold (0.09 log units) below the measured one; the measured number falls inside the stated range.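

In this assay, redrawing the double bond from Z to E gives a 1.2-fold higher number from compound 3 to compound 4 (0.09 log units; within the scatter), so in this pair the geometry of that bond makes no readable difference. Going by these compounds alone, this is the first step that can be read, and it isolates a single change: the fact that compounds 3 and 4 differ only in the configuration as drawn. Within the data shown here, the only earlier step could not be read, since both its values are limits and not numbers: the limit of > 200000 nM in this assay, at which 2 of the 4 values shown sit.

From the compounds shown here alone, it remains open whether the two geometries would still match with another substituent on the double bond, such as an amine or a carboxylic acid.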